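Taking the amino group off compound 1

The source may hold more compounds than are shown below. What is called first, only, known or untested is meant among the compounds shown, and "the series" means these compounds.

Compound 1 `COc1cc2c(cc1OC)C(c1cccc(N)c1)=NN=C(S)C2` gives 18.8 umol/kg
Compound 2 `COc1cc2c(cc1OC)C(c1ccc(Br)cc1)=NNC(=O)C2` gives 110 umol/kg
Compound 3 `COc1cc2c(cc1OC)C(c1ccccc1)=NNC(=O)C2` gives 33.9 umol/kg

In a functional assay on the whole organism with Mus musculus as the target (a higher number here means that more compound is needed for the effect, a lower number that less compound is needed), compound 1 lies within the scatter of compound 3 and well under compound 2. Compound 4 `COc1cc2c(cc1OC)C(c1ccccc1)=NN=C(S)C2`, not yet measured, follows from compound 1 by hydrogen in place of amino on an aromatic carbon. Among the compounds with values here, the one measured step of this kind is a 3.2-fold lower number from compound 2 to compound 3 (0.51 log units; beyond the scatter), which is modest and removes bromo rather than amino, so it bears only loosely. Compound 4 shares the phenyl with compound 3 at 33.9 umol/kg, but differs from it elsewhere in the core. No step beyond the scatter is expected. The estimated step is a 1.5-fold higher number from compound 1 to compound 4 (0.17 log units; within the scatter). For compound 4 the expected value is 28 umol/kg, with an estimated range from 11 umol/kg to 70 umol/kg.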

Compound 4, dose for half-maximal effect: 19.7 umol/kg
Compound 4: the middle estimate sits 1.4-fold (0.15 log units) above what was measured; the range from low to high includes it.
By their numbers in this assay, from the lowest: compounds 1, 4 and 3 (each within the scatter of the next); then compound 2.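

In this assay, the step of a 1.0-fold higher number from compound 1 to compound 4 (0.02 log units; within the scatter) shows that amino on this aromatic carbon, meta to a large group, can be replaced by hydrogen with no change beyond the scatter. The 3-aminophenyl and phenyl compounds therefore cannot be told apart in the core of compound 1, whereas the earlier step, a 3.2-fold lower number from compound 2 to compound 3 (0.51 log units; beyond the scatter), concerned bromo and lay beyond the scatter. Nothing available explains why the amino group makes no measurable difference.

Going by these compounds, whether a hydroxyl, a methoxy or a carboxylic acid on this carbon would behave in the same way remains open.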